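Removing a Fluorine from the Indole of a Hydroxamic Acid

This account rests on a few compounds, and the source may have more. Where it says the series, first, only, none or still open, it means among the compounds named here.

Compound 1: `O=C(COc1ccc(CNC2CC=C(c3c[nH]c4cccc(F)c34)CC2)c(F)c1)NO` — 173 nM
Compound 2: `Cc1[nH]c2ccccc2c1C1=CCC(NC(=O)c2ccc(OCC(=O)NO)cc2)CC1` — > 5000 nM

Of the compounds shown here, two have been measured in a functional assay on HCT-116 cells (Homo sapiens) for antiproliferative activity, with a stated time of 72 h; a lower number here means a stronger inhibitor, a higher number a weaker inhibitor. Going by the values given here, compound 1, with structure `O=C(COc1ccc(CNC2CC=C(c3c[nH]c4cccc(F)c34)CC2)c(F)c1)NO`, is the only one with a number: in this assay compound 1 gives 173 nM. Compound 2, with structure `Cc1[nH]c2ccccc2c1C1=CCC(NC(=O)c2ccc(OCC(=O)NO)cc2)CC1`, gives only a limit of the assay in this assay, > 5000 nM, and it sits at the limit of > 5000 nM in this assay, at which 1 of the 2 values shown sits. With a single number and a single limit, nothing connects the two by a step that differs in one place, so compound 1 stands alone as the only point of reference.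

Compound 3, with structure `O=C(COc1ccc(CNC2CC=C(c3c[nH]c4ccccc34)CC2)c(F)c1)NO`, is not yet measured. It differs from compound 1 by hydrogen in place of fluoro on an aromatic carbon, which amounts to 4-fluoro-1H-indol-3-yl becoming 1H-indol-3-yl. Among the compounds with values here, no measured pair reports what such a change does here. The expectation is therefore a small step in this assay, if any, from compound 1 to compound 3, perhaps toward a weaker inhibitor but not clearly beyond the scatter, so that a 1.5-fold higher number from compound 1 to compound 3 (0.18 log units; within the scatter) is the estimated step. Compound 3 is expected to give about 260 nM in this assay, within a range from 100 nM to 700 nM.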

Compound 3, half-maximal inhibitory concentration: 436 nM
Compound 3: middle estimate off by 1.7-fold (0.22 log units), on the low side, within the range that was stated.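

Going by these compounds alone, this pair gives the first direct reading of this position: hydrogen in place of fluoro on an aromatic carbon gives a 2.5-fold higher number from compound 1 to compound 3 (0.40 log units; beyond the scatter) in this assay and thus a modest change beyond the scatter. The fluoro of 4-fluoro-1H-indol-3-yl therefore matters in this pair, yet it is not essential for a measurable result, since compound 3 with its 1H-indol-3-yl group still gives a number and not a limit of the assay. Nothing among the data shown explains the size or direction of this step, so it stands as an observation only.

As far as these compounds go, what remains open is whether a chlorine atom, a methoxy group or a nitrile on the same aromatic carbon would give a number closer to that of compound 1, further from it, or indistinguishable from it within the scatter. A single pair also leaves open whether hydrogen in place of fluoro would have a step of similar size and direction in a compound that differs elsewhere, for example one carrying a methyl group on the indole or a longer chain to the hydroxamic acid.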